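The source may hold more compounds than are shown below. What is called first, only, known or untested is meant among the compounds shown, and "the series" means these compounds.

Measured so far in a functional assay on MCF7 cells (Homo sapiens) for antiproliferative activity, read by MTT assay, with a stated time of 48 h, tested at 50 uM; a higher number here means a weaker effect of the compound at the concentration tested, a lower number a stronger effect:

compound 1, `OCC(O)Cn1nc2c(Br)c(Br)c(Br)c(Br)c2n1`, gives 109%
compound 2, `OC(CCn1nc2c(Br)c(Br)c(Br)c(Br)c2n1)c1ccccc1`, gives 23%

Two numbers exist in this assay. Among the measured compounds shown here, compound 2 has the lower of the two; the only other number, that of compound 1, lies well above it, and the gap between compound 1 and compound 2 is beyond the usual scatter. For the measured compounds named here, both share the same brominated core; the two differ in the whole side chain, so no single-point step is available between them, and nothing can be read from the pair about any one group.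

Compound 3, `OC(CCn1nc2c(Br)c(Br)c(Br)c(Br)c2n1)c1ccc(F)cc1`, keeps the side chain of compound 2 and differs from it in one place: fluoro in place of hydrogen on an aromatic carbon. The change amounts to phenyl becoming 4-fluorophenyl.

Going by the values given here, no measured step of this kind exists. A single fluorine on the aromatic ring of this side chain is a small change, and no step beyond the scatter is expected in this assay in either direction; the expected step is a number 2 percentage points higher from compound 2 to compound 3 (within the scatter). For compound 3 the expected value in this assay is 25%, with a range from 10% to 50%.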

Compound 3, a percentage reported as activity, at one concentration (the size of the read-out at that concentration, not a potency): 7%
Compound 3: the middle estimate sits 18 percentage points above what was measured; measured number below the stated range.
By their numbers in this assay, from the lowest: compound 3; then compound 2; then compound 1.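

In this assay, fluoro in place of hydrogen on an aromatic carbon, para to a large group, gives a number 16 percentage points lower from compound 2 to compound 3 (beyond the scatter). Among the compounds shown here, this is the first single-point step, and it shows that the phenyl ring of this side chain is not silent in this read-out: one added heavy atom, with the rest of the molecule unchanged, moves the number by a modest but readable amount towards a stronger effect at the one concentration tested, so 4-fluorophenyl stands ahead of phenyl here. Nothing available bears on the reason for this step.

Still open, on these data alone, is whether the step belongs to fluoro itself or would also appear with another group in the same place, such as chloro, methoxy, trifluoromethyl or an amine, and whether fluoro elsewhere on the ring would give a similar number. Also open, as far as these compounds go, is how the hydroxyl group and the length of the chain contribute, since a ketone in place of the alcohol or a longer chain between the core and the ring would each be a separate single-point question.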